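A few compounds are considered here, and "the series" means these few. Any claim that something is new, unique, unknown or untested is made for them only; others in the source may bear on it.

Compound 3 `O=C(N[C@H]1CN(S(=O)(=O)c2ccccc2)C[C@@H]1C(=O)N[C@H]1CCCNC1)c1cc(-c2ccccc2)on1` is the point of departure for the next step. In a functional assay on HEK293 cells for agonist activity at growth hormone secretagogue receptor type 1 (Homo sapiens), read by HTRF and inositol phosphate accumulation, with a stated time of 90 min, in the presence of a further agent that is not named here (a higher number here means a larger maximal response, a lower number a smaller maximal response), compound 3 gives 90%; compound 1 `Cc1ccc2[nH]c(C(=O)N[C@H]3CCN(S(=O)(=O)N4CCOCC4)C[C@@H]3C(=O)NCCN(C)C)cc2c1` gives 98% and compound 2 `O=C(N[C@H]1CN(S(=O)(=O)c2ccccc2)C[C@@H]1C(=O)N[C@H]1CCCNC1)c1cc(C2CC2)n[nH]1` gives 81%, so compound 3 sits in the middle of the three, both gaps falling within the usual scatter. Among the measured compounds shown here, the only single-change step measured so far, a number 9 percentage points higher from compound 2 to compound 3 (within the scatter), exchanged the heteroaryl group on the carbonyl carbon and was itself within the scatter. Compound 4 `O=C(N[C@H]1CN(S(=O)(=O)c2ccccc2)C[C@@H]1C(=O)N[C@H]1CCCNC1)c1cc(-c2ccc(Cl)cc2)on1` differs from compound 3 by chloro in place of hydrogen on an aromatic carbon. For the measured compounds named here, no measured pair exchanges hydrogen for chloro on this ring, so nothing points to a shift beyond the scatter. Compound 4 is therefore expected to give about 88% in this assay, within a range of 74% to 100%. The expected step is a number 2 percentage points lower from compound 3 to compound 4 (within the scatter).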

Compound 4, largest response reached (Emax), in percent of the reference or control that the assay uses: 91%
Estimate against measurement, compound 4: 3 percentage points below; the measured number falls inside the stated range.
By their numbers in this assay, from the lowest: compounds 2, 3, 4 and 1 (each within the scatter of the next, the first and the last beyond it).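

Chloro in place of hydrogen on the phenyl ring gives a number 1 percentage points higher from compound 3 to compound 4 (within the scatter) in this assay, so this position accepts a chlorine atom with no change that can be told from the scatter. The exchange of 3-cyclopropyl-1H-pyrazol-5-yl for 5-(4-chlorophenyl)-1,2-oxazol-3-yl gives a number 10 percentage points higher from compound 2 to compound 4 (within the scatter) and likewise stays inside the scatter. Nothing measured on these compounds bears on the reason for either result.

Going by these compounds, whether a larger change at this ring carbon, such as an amine or a carboxylic acid, would move the maximal response beyond the scatter stays open.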